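Extending the acyl chain in a small amidine series

A few compounds are considered here, and "the series" means these few. Any claim that something is new, unique, unknown or untested is made for them only; others in the source may bear on it.

Of the compounds shown here, three have been tested in an assay on isolated protein for inhibition of Nitric oxide synthase, inducible (Homo sapiens), with a stated time of 30 min, tested at 1 mM; a lower number here means less inhibition, a higher number more inhibition at the concentration tested (going by the name of the read-out). Compound 1 `CCC(=O)N1CCC(c2ccccc2N)=N1` gives 6.88% in this assay, and compound 2 `CCCC(=O)N1CCC(c2ccccc2N)=N1` gives 0.35%. The two differ by methyl in place of hydrogen on a saturated chain carbon, two bonds along the chain from a carbonyl carbon, and the resulting step is a number 6.5 percentage points lower from compound 1 to compound 2 (within the scatter). Compound 3 `CC(=O)N1CCC(c2cc(Cl)ccc2N)=N1` gives 1.03% in this assay; how its core differs from the core of compound 1 is not broken down here. Compound 4 `CCC(=O)N1CCC(c2cc(Cl)ccc2N)=N1` has not yet been measured. It differs from compound 3 by methyl in place of hydrogen on a saturated chain carbon bound to a carbonyl carbon. Within the data shown here, this is the same kind of change as the one between compound 1 and compound 2, though the place is not identical: in compound 1 the carbon taking the new methyl lies two bonds along the chain from a carbonyl carbon, while in compound 3 it is bound to a carbonyl carbon. Because the earlier step of a number 6.5 percentage points lower from compound 1 to compound 2 (within the scatter) stayed within the scatter, and because compound 3 gives 1.03%, little movement is expected. For compound 4 the expected value is 2%, estimated to lie between -5% and 10%. The step this estimate implies is a number 1 percentage points higher from compound 3 to compound 4 (within the scatter).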

Compound 4, a percentage reported as inhibition, at one concentration (the size of the read-out at that concentration, not a potency): 13.7%
For compound 4 the middle estimate is 11.7 percentage points below the measured one, and the stated range ends below it.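

In this assay, the methyl that turns acetyl into propanoyl gives a modest rise, a number 12.7 percentage points higher from compound 3 to compound 4 (beyond the scatter). This shows that the same kind of change does not carry over as a fixed increment from one core to the other, since the two steps differ in size and direction: the same change on two cores in this assay, a number 6.5 percentage points lower (within the scatter) from compound 1 to compound 2 and a number 12.7 percentage points higher (beyond the scatter) from compound 3 to compound 4, 19.2 percentage points apart, beyond the scatter of two such steps

It does not show why they differ, as the new methyl sits at a different place on the chain in each step, so the effect of the core cannot be separated from that of the place, and the exchange of hydrogen for chloro on the propanoyl compounds, a number 6.8 percentage points higher from compound 1 to compound 4 (within the scatter), adds no firm difference of its own.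

Still open, going by these compounds, is how a butanoyl group would read on the core of compound 3, which would put the new methyl at the same place on the chain as in the step from compound 1 to compound 2. Also open, on these data alone, is how a longer chain, or one ending in an amine or a carboxylic acid, would behave on either core.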